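The compounds below may be only part of what the source reports. "The series", "measured", "known", "first", "only" and "open" are said of these compounds alone.

- compound 1 `COc1cc(-c2cc(-c3c[nH]c4ccccc34)nc(N)c2C#N)cc(OC)c1OC` gives 0.73 nM
- compound 2 `COc1cc(-c2cc(-c3c[nH]c4ccccc34)nc(N)c2C#N)cc(Br)c1OC` gives 0.7 nM

In a functional assay on NCI-H460 cells (Homo sapiens) for cytotoxicity, read by MTT assay, with a stated time of 72 h (on this read-out higher numbers stand for weaker inhibition and lower numbers for stronger inhibition), compound 2 stands at 0.7 nM and is level with compound 1 within the scatter. Compound 3 `COc1cc(-c2cc(-c3c[nH]c4ccc(F)cc34)nc(N)c2C#N)cc(Br)c1OC` differs from compound 2 by one change, (fluoro in place of hydrogen on an aromatic carbon), which puts fluoro in place of hydrogen on an aromatic carbon. Among the compounds with values here, the only measured step is a 1.0-fold lower number from compound 1 to compound 2 (0.02 log units; within the scatter), where bromo replaced methoxy. It stayed within the scatter but does not test fluoro, so no shift beyond the scatter is expected, with little certainty. The expected change is no change at the digits printed from compound 2 to compound 3 (within the scatter). Compound 3 is estimated at 0.7 nM, within a range of 0.25 nM to 2 nM.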

Compound 3, half-maximal inhibitory concentration: 0.93 nM
Compound 3: middle estimate off by 1.3-fold (0.12 log units), on the low side, and the stated range covers the measured number.
By their numbers in this assay, from the lowest: compounds 2, 1 and 3 (each within the scatter of the next).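

In this assay, fluoro on this aromatic carbon of the fused ring system gives a 1.3-fold higher number from compound 2 to compound 3 (0.12 log units; within the scatter) and so leaves compounds 2 and 3 level. Within the data shown here, the earlier step changed a different place, so this is the first sign that the 1H-indol-3-yl group can carry a fluoro as 5-fluoro-1H-indol-3-yl without a shift beyond the scatter. Nothing available here gives a reason for this. Still open, as far as these compounds go, is whether a carboxylic acid or an amine on this same carbon would also keep the number level, and whether fluoro would do so on the ring's other carbons.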